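Removing the chloro from compound 3: an expected flat step

A few compounds are considered here, and "the series" means these few. Any claim that something is new, unique, unknown or untested is made for them only; others in the source may bear on it.

Measured so far in a functional assay, read by spectrophotometry, with a stated time of 15 min; a higher number here means a weaker inhibitor, a lower number a stronger inhibitor:
compound 1, `Cc1nc2c3ccccc3ccc2c2nc3c(ccc4ccccc43)c(-c3cccc([N+](=O)[O-])c3)c12`, gives 54.2 ug/mL
compound 2, `COc1ccc(-c2c3ccc4ccccc4c3nc3c2c(C)nc2c4ccccc4ccc32)cc1`, gives 82.3 ug/mL
compound 3, `Cc1nc2c3ccccc3ccc2c2nc3c(ccc4ccccc43)c(-c3ccccc3Cl)c12`, gives 74.6 ug/mL

Compound 3 stands second highest of the three numbers, and all three lie within the scatter of one another: a 1.5-fold higher number from compound 1 to compound 2 (0.18 log units; within the scatter), a 1.4-fold higher number from compound 1 to compound 3 (0.14 log units; within the scatter) and a 1.1-fold lower number from compound 2 to compound 3 (0.04 log units; within the scatter). Each of those steps swaps the whole aryl group on the same aromatic carbon of the shared core, and none of them moves the number beyond the scatter.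

Compound 4, `Cc1nc2c3ccccc3ccc2c2nc3c(ccc4ccccc43)c(-c3ccccc3)c12`, differs from compound 3 by a smaller change on that aryl group: hydrogen in place of chloro on an aromatic carbon. Going by the values given here, the measured steps are the only guide, and they say that exchanging 3-nitrophenyl, 4-methoxyphenyl and 2-chlorophenyl at this place makes no difference that can be told from repeat measurements. Dropping the chloro to give plain phenyl is a lesser change than any of those, so in this assay compound 4 is expected to give a number close to compound 3, with a 1.0-fold higher number from compound 3 to compound 4 (0.00 log units; within the scatter) as the expected step. The estimate for compound 4 is 75 ug/mL, within a range of 45 ug/mL to 125 ug/mL.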

Compound 4, half-maximal inhibitory concentration: 84.6 ug/mL
Estimate against measurement, compound 4: 1.1-fold (0.05 log units) below, within the range that was stated.
By their numbers in this assay, from the lowest: compounds 1, 3, 2 and 4 (each within the scatter of the next).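

Compound 4 has a plain phenyl with no added group, yet in this assay it cannot be told apart from the three compounds that carry one (a 1.1-fold higher number from compound 3 to compound 4 (0.05 log units; within the scatter), a 1.0-fold higher number from compound 2 to compound 4 (0.01 log units; within the scatter) and a 1.6-fold higher number from compound 1 to compound 4 (0.19 log units; within the scatter)). Removing the chloro, the methoxy or the nitro therefore leaves the number within the scatter, so none of these three groups is shown to be needed on this ring for the inhibition seen here. Nothing available explains this flat result.

On these data alone, it remains open whether an amine or a carboxylic acid on this ring, or a longer chain in place of the ring, would move the number beyond the scatter. Since all four numbers lie within the scatter of the next, the compounds shown do not settle whether any change at this place can matter in this assay.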